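The source may report more compounds than this note shows. Statements on the series, on what has been measured and on what is new or still open speak of the compounds shown alone.

The set gathers three measured compounds and one still awaiting its number. Compound 1 `C#CCOc1ccc(CC=C)cc1O`, compound 2 `C=CCc1cc(O)c(O)c(CN2CCC(CCO)CC2)c1` and compound 3 `C=CCc1ccc(OCc2cn(-c3cccc(C#N)c3)nn2)c(O)c1` were all run in a functional assay on MIA PaCa-2 cells (Homo sapiens) for inhibition, read by MTT assay, with a stated time of 72 h, tested at 30 uM; on this read-out lower numbers stand for less inhibition of growth and higher numbers for more inhibition of growth at the one concentration tested. There compound 1 gives 27.4%, and compound 3 gives 26.6%; these two numbers sit close together. Compound 2 gives 54.4%, the highest of the three numbers shown. Its nearest neighbour is compound 1, whose number lies well below it, beyond the usual scatter, and compound 3 stands furthest from it, also beyond the scatter. Compound 2 is thus the one of the three measured compounds that inhibits growth most in this assay.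

Compound 4 `C=CCc1cc(O)c(O)c(CN2CCC(C)CC2)c1` keeps the core of compound 2 and differs from it in a single place: hydrogen in place of hydroxymethyl on a saturated chain carbon bound to a saturated ring carbon. For the measured compounds named here, no pair of measured compounds in this set differs by one change only, so nothing in the data shows how a step of this kind plays out in this assay. The change is small in what it removes and leaves the rest of compound 2 untouched. He expects the step from compound 2 to compound 4 to be a number 8.4 percentage points lower from compound 2 to compound 4 (within the scatter), that is, a modest move downward or none beyond the scatter. Compound 4 is therefore estimated at 46%, within a range from 26% to 64%.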

Compound 4, percent growth inhibition at one concentration: 91.5%
Compound 4: the middle estimate sits 45.5 percentage points below what was measured, and the stated range ends below it.
By their numbers in this assay, from the lowest: compounds 3 and 1 (each within the scatter of the next); then compound 2; then compound 4.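

In this assay, for the compounds shown here, putting hydrogen in place of hydroxymethyl on a saturated chain carbon bound to a saturated ring carbon gives a number 37.1 percentage points higher from compound 2 to compound 4 (beyond the scatter), the first single change in this set that can be read at all. The step shows that this place on the core is sensitive to what it carries, and that here the loss of the hydroxymethyl, which takes away one hydrogen-bond donor and one hydrogen-bond acceptor, goes with more inhibition of growth rather than less, with the rest of the structure left unchanged. Nothing among the data gathered here accounts for the size or direction of this step, so it stands as an observation without an explanation.

One step cannot separate the loss of the hydroxyl oxygen from the shortening of the chain, which the same difference, cut one bond further out, reads as 2-hydroxyethyl to methyl. The compounds shown leave open how an ethyl group, a longer chain, an amine or a carboxylic acid at the same place would compare with the methyl of compound 4 in this assay.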